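A few compounds are considered here, and "the series" means these few. Any claim that something is new, unique, unknown or untested is made for them only; others in the source may bear on it.

Going by the values given here, in a functional assay on CHO cells with adenosine receptor A1 (Homo sapiens) as the target, read by cAMP accumulation and immunoassay, with a stated time of 6 min, tested at 1 uM (a higher number here means a weaker effect of the compound at the concentration tested, a lower number a stronger effect), compound 2 `Nc1scc(CN2CCN(c3ccccc3F)CC2)c1C(=O)c1ccc(Cl)cc1` gives -9.2%, the highest of the two numbers so far, meaning the weaker effect of the pair. Compound 1 `Nc1scc(CN2CCN(c3ccc(Cl)cc3Cl)CC2)c1C(=O)c1ccc(Cl)cc1` gives -54%. Among the compounds with values here, the only measured step, a number 44.8 percentage points higher from compound 1 to compound 2 (beyond the scatter), shows that what sits on the ring attached to the amine nitrogen matters a great deal in this assay. Compound 3 `Nc1scc(CN2CCN(c3c(F)cccc3F)CC2)c1C(=O)c1ccc(Cl)cc1` differs from compound 2 by fluoro in place of hydrogen on an aromatic carbon. This is a smaller change than the one measured, since one halogen is added rather than two being exchanged, so a step of comparable size is not the natural expectation. Still, because the step of a number 44.8 percentage points higher from compound 1 to compound 2 (beyond the scatter) was large, a move towards a lower number for compound 3 is expected, of modest size, a number 8.8 percentage points lower from compound 2 to compound 3 (within the scatter). The estimate for compound 3 in this assay is -18%, within a range from -45% to 8%.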

Compound 3, a percentage reported as activity, at one concentration (the size of the read-out at that concentration, not a potency): -65%
For compound 3 the middle estimate is 47 percentage points above the measured one; measured number outside the range, below it.
By their numbers in this assay, from the lowest: compound 3; then compound 1; then compound 2.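

In this assay, adding a single fluoro to the aromatic ring, turning 2-fluorophenyl into 2,6-difluorophenyl, gives a number 55.8 percentage points lower from compound 2 to compound 3 (beyond the scatter), so this position responds strongly to even the smallest change in heavy atoms. The other comparison, 2,6-difluorophenyl in place of 2,4-dichlorophenyl, gives a number 11 percentage points lower from compound 1 to compound 3 (beyond the scatter), which makes compound 3 the one with the strongest effect of the three at the concentration tested and shows that two chloro groups are not needed for a strong effect. Nothing available explains why this fluoro has so large an effect.

As far as these compounds go, it remains open whether the shift depends on fluoro itself or would also appear with a chloro, methyl or methoxy group in the same place. The three compounds also cannot show how a 2,4-difluorophenyl group would behave.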